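A few compounds are considered here, and "the series" means these few. Any claim that something is new, unique, unknown or untested is made for them only; others in the source may bear on it.

In an ADME assay on L02 cells (Homo sapiens) for cytotoxicity, read by MTT assay, with a stated time of 24 h (on this read-out lower numbers stand for stronger inhibition and higher numbers for weaker inhibition), compound 1 `CN1C/C(=C\c2ccncc2)C(=O)/C(=C/c2ccccc2F)C1` gives 14900 nM and compound 2 `O=C1/C(=C/c2ccncc2)CNC/C1=C\c1ccccc1F` gives 14700 nM. Compound 3 `O=C1/C(=C/c2ccncc2)CN(S(=O)(=O)c2ccc(C(F)(F)F)cc2)C/C1=C\c1ccccc1F`, at 18600 nM, lies within the scatter of both. Compound 4 `O=C1/C(=C/c2ccncc2)CN(S(=O)(=O)c2ccc(Br)cc2)C/C1=C\c1ccccc1F` differs from compound 3 by bromo in place of trifluoromethyl on an aromatic carbon, para to a large group. Among the compounds with values here, the one measured step, a 1.0-fold lower number from compound 1 to compound 2 (0.01 log units; within the scatter), is hydrogen in place of methyl on an amine nitrogen in a ring, so it does not test this aromatic carbon. Within the data shown here, no measured pair varies this group, and no step beyond the scatter is expected in this assay. The estimated step is a 1.1-fold lower number from compound 3 to compound 4 (0.04 log units; within the scatter). Compound 4 is estimated at 17000 nM, with an expected range of 9000 nM to 32000 nM.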

Compound 4, half-maximal inhibitory concentration: 19400 nM
Compound 4: the middle estimate sits 1.1-fold (0.06 log units) below what was measured, within the range that was stated.
By their numbers in this assay, from the lowest: compounds 2, 1, 3 and 4 (each within the scatter of the next).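

In this assay, within the data shown here, bromo in place of trifluoromethyl on the aromatic carbon, para to a large group, gives a 1.0-fold higher number from compound 3 to compound 4 (0.02 log units; within the scatter) and so is the first change at this position, with no step beyond the scatter. On the ring amine nitrogen, (4-bromophenyl)sulfonyl likewise stays within the scatter, with a 1.3-fold higher number from compound 2 to compound 4 (0.12 log units; within the scatter) against hydrogen and a 1.3-fold higher number from compound 1 to compound 4 (0.11 log units; within the scatter) against methyl. No available evidence accounts for these numbers.

As far as these compounds go, whether an amine or a carboxylic acid on this aromatic carbon would give a step beyond the scatter remains open. The same holds for a longer chain on the ring nitrogen.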